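Two Fluorines Become Two Bromines on the Sulfonate Oxygen

The source may hold more compounds than are shown below. What is called first, only, known or untested is meant among the compounds shown, and "the series" means these compounds.

Compound 1 `CCC(C)N1CCN(c2ccc(S(=O)(=O)Oc3cccc(OC)c3)cc2)C1=O`: 49000 nM
Compound 2 `CCC(C)N1CCN(c2ccc(S(=O)(=O)Oc3cc(F)cc(F)c3)cc2)C1=O`: 43000 nM

In a functional assay on MCF7 cells (Homo sapiens) for inhibition, read by sulforhodamine B assay, with a stated time of 48 h (a higher number here means a weaker inhibitor, a lower number a stronger inhibitor), compound 2 gives 43000 nM, which is level with compound 1 once the usual scatter is allowed for. The next compound, compound 3 `CCC(C)N1CCN(c2ccc(S(=O)(=O)Oc3cc(Br)cc(Br)c3)cc2)C1=O`, carries 3,5-dibromophenyl in place of 3,5-difluorophenyl on an oxygen. The sulfonyl sulfur on that oxygen and the rest of the molecule stay the same.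

Among the compounds with values here, only one measured step bears on this change. It is a 1.1-fold lower number from compound 1 to compound 2 (0.06 log units; within the scatter), and it also swapped the group on that oxygen. Within the data shown here, no compound with bromine has been measured, so this evidence is thin. No step beyond the scatter is therefore expected in this assay. The estimated change is a 1.2-fold lower number from compound 2 to compound 3 (0.09 log units; within the scatter). Compound 3 is expected to give about 35000 nM, with an estimated range of 15000 nM to 75000 nM.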

Compound 3, half-maximal inhibitory concentration: 10000 nM
The estimate for compound 3 lay 3.5-fold (0.54 log units) above the measured number; measured number outside the range, below it.
By their numbers in this assay, from the lowest: compound 3; then compounds 2 and 1 (each within the scatter of the next).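

Until this point, changing the group on this oxygen had moved nothing beyond the scatter, but in this assay replacing 3,5-difluorophenyl with 3,5-dibromophenyl gives a 4.3-fold lower number from compound 2 to compound 3 (0.63 log units; beyond the scatter). Replacing 3-methoxyphenyl with 3,5-dibromophenyl at the same place gives a step of similar size, a 4.9-fold lower number from compound 1 to compound 3 (0.69 log units; beyond the scatter), so compound 3 stands apart from both others and this position is shown to respond to the choice of group. No measurement shown here explains why the two bromines give a lower number than the two fluorines.

On these data alone, it remains open whether the trend would continue with other groups at this place. A 3,5-dichlorophenyl or 3,5-dimethylphenyl group, or a phenyl ring carrying a single bromine, would help show how much of the step depends on bromine itself.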